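The source may report more compounds than this note shows. Statements on the series, on what has been measured and on what is new or still open speak of the compounds shown alone.

Measured compounds:
compound 1 `Oc1ccccc1C1CC(c2ccc(Cl)c(Cl)c2)=NN1c1ccccc1`: 1570 nM
compound 2 `c1ccc(N2N=C(c3ccc4c(c3)OCCO4)CC2c2ccco2)cc1`: > 100000 nM
compound 3 `O=C(c1ccc2c(c1)OCCO2)N1N=C(c2ccc(Br)cc2)CC1c1ccccc1F`: 750 nM

In a functional assay on WM 266-4 cells (Homo sapiens) for antiproliferative activity, read by MTT assay, with a stated time of 24 h (on this read-out higher numbers stand for weaker inhibition of growth and lower numbers for stronger inhibition of growth), compound 1 gives 1570 nM and compound 3 gives 750 nM. For compound 2 the result is a limit rather than a number, > 100000 nM. Compound 2 thus sits at the limit of > 100000 nM in this assay, at which 1 of the 3 values shown sits, so its true position relative to compound 1 and compound 3 is not known; the two measured numbers both lie on the side of stronger inhibition of growth than that limit.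

Compound 4 `COc1ccc(C2CC(c3ccc4c(c3)OCCO4)=NN2c2ccccc2)cc1OC` differs from compound 2 in one place: 3,4-dimethoxyphenyl in place of furan-2-yl on a saturated ring carbon. For the measured compounds named here, no step between measured compounds covers this change, and compound 1 and compound 3 differ from compound 2 in several places at once, so they give no direct guide to its size. The expectation is that the change moves compound 4 toward stronger inhibition of growth than the limit of compound 2, by an estimated at least 3.3-fold lower number from compound 2 to compound 4 (0.52 log units; beyond the scatter), though a second limit cannot be excluded. For compound 4 in this assay the estimate is 30000 nM, with a range from 5000 nM to 150000 nM.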

Compound 4, concentration for 50% growth inhibition: 2160 nM
Compound 4: middle estimate off by 14-fold (1.14 log units), on the high side, and the stated range ends above it.
By their numbers in this assay, from the lowest: compound 3; then compounds 1 and 4 (each within the scatter of the next). At a limit, above all of these: compound 2.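

In this assay, the group on the saturated ring carbon next to the ring nitrogen has a large bearing on the result: 3,4-dimethoxyphenyl in place of furan-2-yl gives an at least 46-fold lower number from compound 2 to compound 4 (1.66 log units; beyond the scatter). Compound 4 gives 2160 nM, which shows that this position can give a measured number on the shared core. The step is a lower bound on the change and not its full size. Compound 2 stands at a limit and not at a number: the limit of > 100000 nM in this assay, at which 1 of the 4 values shown sits.

From the compounds shown here alone, whether the step belongs to the six-membered aromatic ring itself or to its two methoxy groups stays open, and a plain phenyl or a thiophen-2-yl group on the same ring carbon would separate the two. Also open, going by these compounds, is whether the same change holds on a core with a different group on the ring nitrogen, such as the carbonyl-linked group of compound 3, or with a halogen-bearing phenyl on the other side of the core.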